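The source may report more compounds than this note shows. Statements on the series, on what has been measured and on what is new or still open speak of the compounds shown alone.

Measured compounds:
- compound 1, `COc1cc(/C=N/NC(=O)Nc2cccc3ccccc23)cc(OC)c1OC`, in a functional assay on the whole organism (strain Swiss albino) with Mus musculus as the target, in the maximal electroshock model, with a stated time of 4 h (a lower number here means that less compound is needed, a higher number that more compound is needed for the effect), gives 100 mg/kg
- compound 2, `O=C(N/N=C/c1ccc(F)cc1)Nc1cccc2ccccc12`, in this assay gives 300 mg/kg

Of the two numbers, compound 2 holds the highest: the nearest neighbour, compound 1, needs a dose that is lower by an amount beyond the usual scatter of repeated measurements, so the gap between the two is a real one and not noise. Both share the same core, a naphthyl-bearing semicarbazone, and differ only in the aryl group attached to the carbon with a double bond to nitrogen.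

Compound 3, `COc1cccc(/C=N/NC(=O)Nc2cccc3ccccc23)c1`, is not yet measured. It differs from compound 2 in one place: 3-methoxyphenyl in place of 4-fluorophenyl on a carbon with a double bond to nitrogen. Within the data shown here, no comparable step between measured compounds is available, so the direction of the change rests on what the two measured numbers show. Compound 1, whose aryl group carries methoxy groups, gives a lower dose than compound 2, so a modest move towards a lower dose is expected, though a single methoxy group may not carry the whole of that shift. The expected step from compound 2 to compound 3 is a 1.5-fold lower number from compound 2 to compound 3 (0.18 log units; within the scatter). For compound 3 the estimate in this assay is 200 mg/kg, with a range from 100 mg/kg to 600 mg/kg.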

Compound 3, minimum effective dose: 300 mg/kg
Compound 3: the middle estimate sits 1.5-fold (0.18 log units) below what was measured; low and high end bracket the measured number.
By their numbers in this assay, from the lowest: compound 1; then compounds 2 and 3 (each within the scatter of the next).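

In this assay, among these compounds, replacing 4-fluorophenyl with 3-methoxyphenyl on a carbon with a double bond to nitrogen gives no change at the digits printed from compound 2 to compound 3 (within the scatter) and is the first direct one-place comparison at this position. This exchange adds a hydrogen-bond acceptor and one heavy atom, yet the dose needed stays level, so neither that added acceptor nor the loss of fluorine shows any effect on the read-out here. A single methoxy group also does not reach the dose seen for compound 1 at 100 mg/kg in a compound whose aryl group carries several methoxy groups, so one such group alone does not reproduce that lower number, and no measurement at hand gives a reason for this result.

As far as these compounds go, it remains open whether the lower dose of compound 1 depends on the number of methoxy groups, on where they sit, or on both. The effect at this carbon of an unsubstituted phenyl, or of a phenyl ring bearing an amine or a carboxylic acid, also remains unknown from the compounds shown.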